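Swapping a hydroxy for a methoxy on a weak inhibitor

The source may report more compounds than this note shows. Statements on the series, on what has been measured and on what is new or still open speak of the compounds shown alone.

- compound 1 `COc1ccc(/C=C/C(=O)c2c(OC)cc(O)c(CC=C(C)C)c2O)cc1OC` gives 15700 nM
- compound 2 `COc1cc(/C=C/C(=O)c2c(O)cc(O)cc2OC)ccc1O` gives > 50000 nM

In a functional assay on A549 cells (Homo sapiens) for inhibition, read by MTT assay, with a stated time of 72 h (a lower number here means a stronger inhibitor, a higher number a weaker inhibitor), compound 1 gives 15700 nM as a true number. Compound 2 reads > 50000 nM (a limit of the assay, not a number). Compound 3 `COc1ccc(/C=C/C(=O)c2c(O)cc(O)cc2OC)cc1OC` differs from compound 2 by one change, hydroxy to methoxy (methyl in place of hydrogen on an oxygen on an aromatic ring), with methyl in place of hydrogen on an oxygen on an aromatic ring. For the measured compounds named here, no measured pair shows this change, so only a modest move towards stronger inhibition is expected in this assay, with compound 1 at 15700 nM (the one true number) as the nearest guide. The estimated step (an at least 1.2-fold lower number from compound 2 to compound 3 (0.09 log units; that floor lies within the scatter)) is small. For compound 3 the expected value is 40000 nM (estimated range 15000 nM to 80000 nM).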

Compound 3, half-maximal inhibitory concentration: > 50000 nM
Compound 3: a limit, no number (the forecaster's own chance of this, stated with the estimate: 45%); middle value at least 1.2-fold (0.09 log units) away from the limit.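

Adding the methyl on this oxygen does not bring the compound into the readable range of this assay: compound 3, like compound 2, is only a limit and not a number. For the compounds shown here, the step between compound 2 and compound 3 cannot be read, because both stop at the same limit: the limit of > 50000 nM in this assay, at which 2 of the 3 values shown sit. The one readable step is an at least 3.1-fold higher number from compound 1 to compound 3 (0.50 log units; beyond the scatter), with hydrogen in place of 3-methylbut-2-en-1-yl on an aromatic carbon.

Going by these compounds, whether the methyl matters at all stays open, since neither compound gives a true number. Also open, on these data alone, is how an amine or a longer chain on that aromatic carbon would read in this assay.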